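This account rests on a few compounds, and the source may have more. Where it says the series, first, only, none or still open, it means among the compounds named here.

Of the compounds shown here, three have so far been measured in a functional assay on HT-29 cells (Homo sapiens) for cytotoxicity, read by sulforhodamine B assay; a higher number here means a weaker inhibitor, a lower number a stronger inhibitor. Compound 1 `C=C1[C@@H](C/C=C2/C(=O)OC[C@H]2OC(C)=O)[C@]2(C)CC[C@@H](OC(C)=O)[C@@](C)(CO[Si](C)(C)C(C)(C)C)[C@H]2C[C@@H]1O` gives 9310 nM. Compound 3 `C=C1[C@@H](OC(C)=O)C[C@@H]2[C@](C)(CO[Si](C)(C)C(C)(C)C)[C@H](OC(C)=O)CC[C@@]2(C)[C@@H]1C[C@@H](Nc1cccc(F)c1)C1=CCOC1=O` gives 4520 nM. Compound 2 `C=C1[C@@H](OC(C)=O)C[C@@H]2[C@](C)(COC=O)[C@H](OC(C)=O)CC[C@@]2(C)[C@@H]1C[C@@H](Nc1ccccc1C(=O)O)C1=CCOC1=O` gives 28700 nM, the highest of the three numbers, so compound 2 is the weakest inhibitor of this set; its nearest neighbour is compound 1 and its furthest is compound 3, and both gaps lie beyond the scatter of the assay.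

Compound 4 `C=C1[C@@H](OC(C)=O)C[C@@H]2[C@](C)(COC=O)[C@H](OC(C)=O)CC[C@@]2(C)[C@@H]1C[C@@H](Nc1ccccc1)C1=CCOC1=O` has not yet been measured. It differs from compound 2 in one place, (hydrogen in place of carboxy on an aromatic carbon), which reads, cut one bond further out, as 2-carboxyphenyl to phenyl, or (2-carboxyphenyl)amino to anilino.

Among the measured compounds shown here, no step between measured compounds that differ in one place is available to calibrate this change. Compound 3 differs from compound 2 in more than one place; in this assay compound 3 gives 4520 nM and serves only as a loose reference. The expectation for compound 4 in this assay is therefore a modest step of a 2.2-fold lower number from compound 2 to compound 4 (0.34 log units; beyond the scatter) toward a lower number. The estimate for compound 4 in this assay is 13000 nM, expected to fall between 4500 nM and 38000 nM.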

Compound 4, half-maximal inhibitory concentration: 28800 nM
Compound 4: the middle estimate sits 2.2-fold (0.35 log units) below what was measured, and the stated range covers the measured number.
By their numbers in this assay, from the lowest: compound 3; then compound 1; then compounds 2 and 4 (each within the scatter of the next).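

In this assay, the exchange of carboxy for hydrogen on the aromatic carbon, ortho to a large group, gives a 1.0-fold higher number from compound 2 to compound 4 (0.00 log units; within the scatter) and so leaves the two compounds indistinguishable. Among the compounds shown here, this is the first single change that can be read in this set, and it shows that the 2-carboxyphenyl and phenyl forms read alike here, so carboxy, with its three heavy atoms, is not required for the level of cytotoxicity seen with compound 2. No supporting measurement accompanies this result to account for it.

The compounds shown leave open whether an amine, a methyl ester or a hydroxyl group at this same aromatic carbon would also read alike. They also leave open whether carboxy would make as little difference at another carbon of the ring.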